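The source may report more compounds than this note shows. Statements on the series, on what has been measured and on what is new or still open speak of the compounds shown alone.

The measured compounds are:

compound 1, `Cc1nc(SCC(=O)Nc2nc(-c3ccc(Cl)cc3)cs2)n(Nc2ccccc2)c1C` — 40100 nM
compound 2, `Cc1ccc(Nn2c(SCC(=O)Nc3nc(-c4ccccc4)cs3)nc(C)c2C)cc1` — > 100000 nM

Among the compounds with values here, in a functional assay on A549 cells (Homo sapiens) for antiproliferative activity, read by sulforhodamine B assay, with a stated time of 48 h (a lower number here means that less compound is tolerated, a higher number that more compound is tolerated), compound 1 gives 40100 nM, and this is the only numerical value among the two. For compound 2 the result in this assay is a limit of the assay and not a number, at > 100000 nM. Within the data shown here, compound 1 therefore stands as the one compound with a determined concentration, whereas compound 2 sits at the limit of > 100000 nM in this assay, at which 1 of the 2 values shown sits.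

Compound 3, `COc1ccc(Nn2c(SCC(=O)Nc3nc(-c4ccc(Cl)cc4)cs3)nc(C)c2C)cc1`, has not yet been measured in this assay. It differs from compound 1 by methoxy in place of hydrogen on an aromatic carbon of the anilino ring. Among the measured compounds shown here, no step between two measured compounds that differ in this one place is available, so the size of such a change cannot be read from the data. The expectation is a step in this assay of no more than the usual scatter, with a fair chance that the assay reports only a limit. Compound 3 is estimated at 50000 nM, between 18000 nM and 100000 nM, which means an expected step of a 1.2-fold higher number from compound 1 to compound 3 (0.10 log units; within the scatter).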

Compound 3, concentration lethal to 50% of the cells: > 100000 nM
Compound 3: no number, only a limit (the forecaster's own chance of this, stated with the estimate: 35%); at least 2.0-fold (0.30 log units) between middle value and limit.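

In this assay, within the data shown here, compound 3 supplies the first step that can be read at this position: methoxy in place of hydrogen on an aromatic carbon of the anilino ring, para to a large group, gives an at least 2.4-fold higher number from compound 1 to compound 3 (0.39 log units; beyond the scatter). Compound 3 gives > 100000 nM, which is a limit of the assay and not a number. Compound 3 thus adds to the results that end at a limit, which leaves a single determined number among the compounds shown: the limit of > 100000 nM in this assay, at which 2 of the 3 values shown sit.

The compounds shown leave open how far beyond the limit compound 3 lies, so only the lower bound of this step is known, not its full size. They also leave open whether another group on the same aromatic carbon, such as a fluorine, a hydroxyl or a carboxylic acid, would give a determined number in this assay or would also end at the limit.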